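The source may hold more compounds than are shown below. What is called first, only, known or untested is meant among the compounds shown, and "the series" means these compounds.

Measured in a physicochemical assay for metabolic stability, in phosphate buffer, at pH 7.4; a higher number here means that the compound lasts longer, a lower number that the compound disappears faster:
- compound 1 `Cc1nc(C)c(COC(=O)NCC(=O)Oc2ccc(-c3cc(=O)c4c(O)c(O)c(O)cc4o3)cc2)nc1C`: 14.3 h
- compound 2 `Cc1nc(C)c(COC(=O)N[C@@H](C(=O)Oc2ccc(-c3cc(=O)c4c(O)c(O)c(O)cc4o3)cc2)C(C)C)nc1C`: 45.6 h
- compound 3 `Cc1nc(C)c(COC(=O)N[C@H](CC(C)C)C(=O)Oc2ccc(-c3cc(=O)c4c(O)c(O)c(O)cc4o3)cc2)nc1C`: 57.2 h

Compound 3 and compound 2 lie within the scatter of each other, and both stand clear of compound 1. The next change gives compound 4 `CC[C@H](C)[C@@H](NC(=O)OCc1nc(C)c(C)nc1C)C(=O)Oc1ccc(-c2cc(=O)c3c(O)c(O)c(O)cc3o2)cc1`: sec-butyl in place of isobutyl on a saturated chain carbon bound to an amide-type nitrogen and a carbonyl carbon. Isopropyl or isobutyl in place of hydrogen at that carbon gave a 3.2-fold higher number from compound 1 to compound 2 (0.50 log units; beyond the scatter) and a 4.0-fold higher number from compound 1 to compound 3 (0.60 log units; beyond the scatter). Isobutyl in place of isopropyl gave only a 1.3-fold higher number from compound 2 to compound 3 (0.10 log units; within the scatter), and this exchange between two chains is the closest precedent. No step beyond the scatter is therefore expected, and the expected step is a 1.1-fold lower number from compound 3 to compound 4 (0.04 log units; within the scatter). For compound 4 the estimate is 52 h, with an expected range of 32 h to 85 h.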

Compound 4, half-life: 64.8 h
Compound 4: the middle estimate sits 1.2-fold (0.10 log units) below what was measured, within the range that was stated.
By their numbers in this assay, from the lowest: compound 1; then compounds 2, 3 and 4 (each within the scatter of the next).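

In this assay the carbon bound to an amide-type nitrogen and a carbonyl carbon shows no response to the shape of a four-carbon chain: sec-butyl in place of isobutyl gives a 1.1-fold higher number from compound 3 to compound 4 (0.05 log units; within the scatter) and the extra methyl gives a 1.4-fold higher number from compound 2 to compound 4 (0.15 log units; within the scatter). Sec-butyl in place of hydrogen gives a 4.5-fold higher number from compound 1 to compound 4 (0.66 log units; beyond the scatter), so a third branched chain clears the scatter against hydrogen and compound 2, compound 3 and compound 4 sit at one level. Nothing available explains this level. From the compounds shown here alone, whether a longer chain, an amine or a carboxylic acid at that carbon would stay at this level remains open.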